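This account rests on a few compounds, and the source may have more. Where it says the series, first, only, none or still open, it means among the compounds named here.

Of the compounds shown here, two with the same core have been measured in an assay on isolated protein (Cavia porcellus) with Sigma non-opioid intracellular receptor 1 (Homo sapiens) as the target, read by radioligand binding; on this read-out higher numbers stand for weaker inhibition and lower numbers for stronger inhibition. Compound 1 `O=c1cc(-c2ccccc2)oc2ccc(OCCCCCCN3CCCCC3)cc12` gives 101 nM in this assay, and compound 2 `CCN(CC)CCCCCCOc1ccc2oc(-c3ccccc3)cc(=O)c2c1` gives 91 nM. Going by the values given here, the only step between them, a 1.1-fold lower number from compound 1 to compound 2 (0.05 log units; within the scatter), swaps one terminal amine for another, so compound 2 stands on the lower of the two numbers, though within the scatter of compound 1. Compound 3 `O=c1cc(-c2ccccc2)oc2ccc(OCCCCCCN3CCNC(CCO)C3)cc12` has not yet been measured; it differs from compound 2 by 3-(2-hydroxyethyl)piperazin-1-yl in place of diethylamino on a saturated chain carbon, six bonds along the chain from an oxygen on an aromatic ring. Among the compounds with values here, the one measured step that bears on this position was flat, but it exchanged two simple amines, whereas the new group brings a second nitrogen and a hydroxyethyl arm, for which no measured pair exists. Compound 3 is therefore expected to lie near, or somewhat weaker than, compound 2, giving an estimated 250 nM with a range of 60 nM to 1000 nM. The expected step, a 2.7-fold higher number from compound 2 to compound 3 (0.44 log units; beyond the scatter), carries this uncertainty.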

Compound 3, half-maximal inhibitory concentration: 63 nM
For compound 3 the middle estimate is 4.0-fold (0.60 log units) above the measured one; low and high end bracket the measured number.
By their numbers in this assay, from the lowest: compounds 3, 2 and 1 (each within the scatter of the next).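

In this assay, placing 3-(2-hydroxyethyl)piperazin-1-yl on a saturated chain carbon, six bonds along the chain from an oxygen on an aromatic ring, gives a 1.4-fold lower number from compound 2 to compound 3 (0.16 log units; within the scatter), and the same group gives a 1.6-fold lower number from compound 1 to compound 3 (0.20 log units; within the scatter). The earlier step had compared only diethylamino and piperidin-1-yl, whereas these steps show that a group of 9 heavy atoms, with a second nitrogen and a hydroxyethyl arm, also stays within the scatter of both at this position. Nothing at hand gives a reason for this flat picture.

The compounds shown leave open whether a plain piperazin-1-yl or a morpholin-4-yl would stay within this range, and so what the hydroxyethyl arm does by itself. They also leave open how a shorter chain, or an amide in place of the amine, would read.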